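Fluorine for chlorine on the sulfonyl ring of compound 3

The source may hold more compounds than are shown below. What is called first, only, known or untested is meant among the compounds shown, and "the series" means these compounds.

Three sulfonamides built on one shared core were tested in an ADME assay on HEK293 cells (Homo sapiens) for cytotoxicity, read by resazurin assay, with a stated time of 48 h; on this read-out lower numbers stand for higher toxicity in this test and higher numbers for lower toxicity in this test. Compound 1 `COc1ccc(S(=O)(=O)Nc2ccc(-c3nc4ccccc4o3)cc2)cc1` reached only a limit of this assay, given as > 100000 nM. Compound 2 `Cc1ccccc1S(=O)(=O)Nc1ccc(-c2nc3ccccc3o2)cc1` likewise stands at a limit, > 100000 nM. Compound 3 `O=S(=O)(Nc1ccc(-c2nc3ccccc3o2)cc1)c1ccccc1Cl` also shows no number but a limit, > 100000 nM. The steps a step that the two limits leave unreadable from compound 1 to compound 2, a step that the two limits leave unreadable from compound 1 to compound 3 and a step that the two limits leave unreadable from compound 2 to compound 3 cannot be sized because every value shown sits at the limit of > 100000 nM in this assay, at which 3 of the 3 values shown sit.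

Compound 4 `O=S(=O)(Nc1ccc(-c2nc3ccccc3o2)cc1)c1ccccc1F` is the next compound. Among the measured compounds shown here, its single change from compound 3 is fluoro in place of chloro on an aromatic carbon. Among the measured steps, the one from compound 2 to compound 3 concerns the same aromatic carbon, but its size is not readable, so no measured step gives a direction or a size for the change to compound 4. What the three limits together suggest is that compound 4 will again show no number in this assay. Compound 4 is therefore expected to sit at about 150000 nM, with a range from 50000 nM to 500000 nM. The step this estimate implies, a step that the limit leaves unreadable from compound 3 to compound 4, is expected to lie within the scatter.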

Compound 4, half-maximal cytotoxic concentration: > 100000 nM
Compound 4: a limit, no number (the forecaster's own chance of this, stated with the estimate: 85%); the middle value is on the limit's open side.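

Compound 4, like compound 1, compound 2 and compound 3, shows no number in this assay, so no new step to compound 4 can be read, because all four stand at the same limit: the limit of > 100000 nM in this assay, at which 4 of the 4 values shown sit.

The compounds shown leave open whether any group on the sulfonyl ring would give a readable number in this assay, and so how these four compare.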